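Six-substituted uridine triphosphates in a P2Y6 agonist read-out

This account rests on a few compounds, and the source may have more. Where it says the series, first, only, none or still open, it means among the compounds named here.

Measured so far, in an in vitro functional assay on 1321-N1 cells for agonist activity at P2Y purinoceptor 6 (Homo sapiens); on this read-out higher numbers stand for an effect only at larger amounts of compound and lower numbers for an effect already at smaller amounts:
- compound 1 `Cn1c(=O)ccn([C@@H]2O[C@H](COP(=O)(O)OP(=O)(O)OP(=O)(O)O)[C@@H](O)[C@H]2O)c1=O`: > 1000 nM
- compound 2 `Cc1cc(=O)n([C@@H]2O[C@H](COP(=O)(O)OP(=O)(O)OP(=O)(O)O)[C@@H](O)[C@H]2O)c(=O)[nH]1`: > 1000 nM

Both values are limits of this assay, not numbers. In this assay compound 1 gives > 1000 nM, a limit. Compound 2 gives > 1000 nM in this assay, again a limit. For the measured compounds named here, the step that the two limits leave unreadable from compound 1 to compound 2 is therefore unreadable; the only evidence is the limit of > 1000 nM in this assay, at which 2 of the 2 values shown sit.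

Compound 3 `CCCc1cc(=O)n([C@@H]2O[C@H](COP(=O)(O)OP(=O)(O)OP(=O)(O)O)[C@@H](O)[C@H]2O)c(=O)[nH]1` differs from compound 2 by ethyl in place of hydrogen on a saturated chain carbon bound to an aromatic carbon. Going by the values given here, no measured step bears on this change, so nothing beyond the limit is expected. Compound 3 is estimated at 3000 nM (range 500 nM to 20000 nM), an expected step that the limit leaves unreadable from compound 2 to compound 3.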

Compound 3, half-maximal effective concentration: > 100000 nM
Compound 3: a limit, no number; the forecaster's own chance of this, stated with the estimate: 75%; middle value at least 33-fold (1.52 log units) away from the limit.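

In this assay compound 2 gives > 1000 nM, a limit. Compound 3 gives > 100000 nM, also a limit, so no step can be read between compound 2 and compound 3. On these data alone, whether methyl to propyl changes the read-out at all, and in which direction, stays open.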